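Formyl Replaces Methoxy on the Pendant Phenyl Ring

This account rests on a few compounds, and the source may have more. Where it says the series, first, only, none or still open, it means among the compounds named here.

Compound 1 `Brc1cn2ccnc2c(-c2ccc3ncn(C4CCCCC4)c3c2)n1`: 5.21%
Compound 2 `c1ccc(-c2cn3ccnc3c(-c3ccc4ncn(C5CCCCC5)c4c3)n2)cc1`: 48.3%
Compound 3 `COc1ccc(-c2cn3ccnc3c(-c3ccc4ncn(C5CCCCC5)c4c3)n2)cc1`: 92.5%

In a functional assay on HT-29 cells (Homo sapiens) for inhibition, read by sulforhodamine B assay, with a stated time of 48 h, tested at 10 uM (a higher number here means more inhibition at the concentration tested (going by the name of the read-out), a lower number less inhibition), compound 3 gives 92.5%, the highest of the three numbers, with compound 2 the nearest and compound 1 the furthest behind. The two steps that reach it are both large: a number 87.3 percentage points higher from compound 1 to compound 3 (beyond the scatter) and a number 44.2 percentage points higher from compound 2 to compound 3 (beyond the scatter). Among the compounds with values here, the first step on that path, a number 43.1 percentage points higher from compound 1 to compound 2 (beyond the scatter), is also large. Compound 4 `O=Cc1ccc(-c2cn3ccnc3c(-c3ccc4ncn(C5CCCCC5)c4c3)n2)cc1` differs from compound 3 by formyl in place of methoxy on an aromatic carbon. Within the data shown here, the step that bears most directly on this change is the one from compound 2 to compound 3, since it alters the same para position; but it replaces hydrogen, not one substituent by another, so no measured step tells how formyl compares with methoxy there. Compound 2 shows that a bare phenyl still gives a middling number, so compound 4 is expected to stay well above compound 1. Compound 4 is estimated at 70%, in the range 35% to 95%. That estimate means a step of a number 22.5 percentage points lower from compound 3 to compound 4 (beyond the scatter), expected to be downward but of uncertain size.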

Compound 4, a percentage reported as inhibition, at one concentration (the size of the read-out at that concentration, not a potency): 17.5%
For compound 4 the middle estimate is 52.5 percentage points above the measured one; the measured number lies below the stated range.
By their numbers in this assay, from the lowest: compound 1; then compound 4; then compound 2; then compound 3.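

In this assay the exchange of methoxy for formyl gives a number 75 percentage points lower from compound 3 to compound 4 (beyond the scatter), although the two groups match in heavy atoms and hydrogen-bond acceptors, so those counts do not settle the outcome at this position. Formyl also falls short of hydrogen, with a number 30.8 percentage points lower from compound 2 to compound 4 (beyond the scatter), which shows that a substituent here can lower the number as well as raise it, whereas methoxy had only raised it. The 4-formylphenyl group keeps just a number 12.3 percentage points higher from compound 1 to compound 4 (beyond the scatter), and nothing measured on these compounds explains why the two groups part so widely.

As far as these compounds go, it remains open whether methoxy is unusual at this place or formyl is, since only these two substituents can be compared. An amine, a hydroxymethyl, a carboxylic acid or a longer ether chain such as ethoxy could help show which.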